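Ketone isostere series: loss of one drawn stereocentre

The compounds below may be only part of what the source reports. "The series", "measured", "known", "first", "only" and "open" are said of these compounds alone.

Compound 1 `CC(C)CCNC(=O)C(C)NC(=O)C(Cc1ccccc1)C[C@H](O)[C@H](CC(C)C)NC(=O)C(NC(=O)CC(C)C)C(C)C` sets the reference: in an assay on isolated protein for inhibition of Pepsin A (Sus scrofa) (a higher number here means a weaker inhibitor, a lower number a stronger inhibitor), compound 1 gives 2.5 nM. Compound 2 `CC(C)CCNC(=O)C(C)NC(=O)[C@@H](CC(=O)[C@H](CC(C)C)NC(=O)C(NC(=O)CC(C)C)C(C)C)Cc1ccccc1` carries the keto analogue of the same chain and in this assay compound 2 gives 850 nM, the higher of the two numbers recorded so far, and the gap to compound 1 lies well beyond the scatter.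

Compound 3 `CC(C)CCNC(=O)C(C)NC(=O)C(CC(=O)[C@H](CC(C)C)NC(=O)C(NC(=O)CC(C)C)C(C)C)Cc1ccccc1` has not been measured. It differs from compound 2 only in this: the two compounds have the same atoms and bonds; at least one stereo element is drawn with a configuration in one of them and without one in the other: 1 of 4 stereo elements differ; a stereocentre at a saturated chain carbon is drawn R in compound 2 and without a configuration in compound 3. With no defined configuration at that chain carbon, compound 3 is read as a mixture of both epimers, one of which is compound 2 itself. The expected step in this assay is therefore small, at most a modest move in either direction and possibly none beyond the scatter, since a mixture can only dilute or slightly improve on the value of compound 2 850 nM. For compound 3 the expected value in this assay is 600 nM, with a range of 150 nM to 2500 nM, which corresponds to an estimated step of a 1.4-fold lower number from compound 2 to compound 3 (0.15 log units; within the scatter).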

Compound 3, inhibition constant: 72 nM
Compound 3: middle estimate off by 8.3-fold (0.92 log units), on the high side, outside the stated range (below it).
By their numbers in this assay, from the lowest: compound 1; then compound 3; then compound 2.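

At this chain carbon the drawn configuration carries real weight in this assay: the step is a 12-fold lower number from compound 2 to compound 3 (1.07 log units; beyond the scatter), and it is the only difference the two structures show: the fact that one of compounds 2 and 3 is drawn with a defined configuration and the other without, at the place where they differ

If compound 3 is a mixture of both epimers, compound 2 cannot be the component that sets its number, so the stronger binding would have to come from the epimer not drawn as compound 2. That makes the R configuration at this carbon the unfavourable one in the keto series, which a mixture reading alone did not predict.

Going by these compounds, how far the other epimer on its own would go, and the actual ratio of epimers in compound 3, stay open. Also open, on these data alone, is whether an amine in place of the ketone carbonyl would show the same dependence on configuration at this chain carbon.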